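Fluoro in place of methyl on the core of compound 2

The source may hold more compounds than are shown below. What is called first, only, known or untested is meant among the compounds shown, and "the series" means these compounds.

Measured so far:
Compound 1 `Cc1cc(N2CCNCC2)c2c(c1)N(S(=O)(=O)c1ccccc1)CCO2` gives 2.51 nM in an assay on HEK293 cells for displacement of a labelled ligand from 5-hydroxytryptamine receptor 6 (Homo sapiens); on this read-out higher numbers stand for weaker inhibition and lower numbers for stronger inhibition.
Compound 2 `Cc1cc(N2CCNCC2)c2c(c1)N(S(=O)(=O)c1ccccc1F)CCO2` gives 0.398 nM in this assay.

Compound 2 stands lowest of the two numbers in this assay; its nearest neighbour is compound 1, and the step of a 6.3-fold lower number from compound 1 to compound 2 (0.80 log units; beyond the scatter) lies beyond the scatter.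

Compound 3 `O=S(=O)(c1ccccc1F)N1CCOc2c(N3CCNCC3)cc(F)cc21` is not yet measured. It differs from compound 2 by fluoro in place of methyl on an aromatic carbon.

For the measured compounds named here, only one measured step exists, a 6.3-fold lower number from compound 1 to compound 2 (0.80 log units; beyond the scatter), and it concerns fluoro replacing hydrogen, not fluoro replacing methyl, and it sits on a different part of the structure. Going by the values given here, no measured pair bears directly on the change from compound 2 to compound 3. With nothing to support a shift either way, the expectation for compound 3 in this assay is a step of no more than the scatter, in no set direction.

Compound 3 is therefore estimated at 0.5 nM, with a range of 0.2 nM to 1.5 nM. This estimate means a step of a 1.3-fold higher number from compound 2 to compound 3 (0.10 log units; within the scatter) that is expected to stay within the scatter.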

Compound 3, inhibition constant: 0.631 nM
The estimate for compound 3 lay 1.3-fold (0.10 log units) below the measured number; the range from low to high includes it.
By their numbers in this assay, from the lowest: compounds 2 and 3 (each within the scatter of the next); then compound 1.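

In this assay, fluoro in place of methyl on this aromatic carbon, para to a fused ring and meta to the piperazin-1-yl group, gives a 1.6-fold higher number from compound 2 to compound 3 (0.20 log units; within the scatter). For the compounds shown here, this is the first measured change on the core itself, and it shows that this carbon accepts fluoro in place of methyl with no shift that can be told from the scatter, whereas a 6.3-fold lower number from compound 1 to compound 2 (0.80 log units; beyond the scatter) lies elsewhere in the structure and beyond the scatter. Nothing available explains this result or shows what the exchange does outside this binding read-out.

Going by these compounds, whether chloro, methoxy or an amine on this carbon would also stay within the scatter of compound 2 remains open. So does whether the fluoro step seen between the first two compounds would carry over to a core bearing fluoro, as in compound 3.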